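The compounds below may be only part of what the source reports. "The series", "measured", "known", "first", "only" and "open" are said of these compounds alone.

Measured so far in a functional assay on the whole organism for inhibition, with Rattus norvegicus as the target; on this read-out lower numbers stand for an effect already at smaller amounts and higher numbers for an effect only at larger amounts of compound:
- compound 1 `O=C(O)CN1C(=O)[C@@H](NC(=O)[C@@H](S)Cc2ccccc2)COc2ccccc21` gives 0.26 umol/kg 
- compound 2 `O=C(O)CN1C(=O)[C@@H](NC(=O)[C@@H](CS)Cc2ccccc2)COc2ccccc21` gives 5.8 umol/kg 

Compound 1 holds the lower number of the two, and its gap to compound 2 lies beyond the scatter. Compound 3 `O=C(O)CCN1C(=O)[C@@H](NC(=O)[C@@H](S)Cc2ccccc2)COc2ccccc21` has not yet been measured. It keeps the core of compound 1 and differs in one place, where carboxymethyl stands in place of carboxy on a saturated chain carbon bound to an amide-type nitrogen in a ring: carboxymethyl in place of carboxy on a saturated chain carbon bound to an amide-type nitrogen in a ring 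

Read one bond further out, this is carboxymethyl to 2-carboxyethyl. Among the measured compounds shown here, only one measured step bears on it, and only indirectly. That step, a 22-fold higher number from compound 1 to compound 2 (1.35 log units; beyond the scatter), is large and also puts sulfanylmethyl in place of sulfanyl, but it lies elsewhere in the molecule. Nothing measured yet tests the carboxymethyl place itself. A rise in the number is therefore expected, probably smaller than that step, and with wide uncertainty. The expected change is a 3.8-fold higher number from compound 1 to compound 3 (0.59 log units; beyond the scatter) as an estimate. For compound 3 the estimated value is 1 umol/kg with an expected range from 0.2 umol/kg to 6 umol/kg in this assay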

Compound 3, dose for half-maximal effect: 1.2 umol/kg
The estimate for compound 3 lay 1.2-fold (0.08 log units) below the measured number; the measured number falls inside the stated range.
By their numbers in this assay, from the lowest: compound 1; then compound 3; then compound 2.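

In this assay, the change from carboxymethyl to 2-carboxyethyl, on a saturated chain carbon bound to an amide-type nitrogen in a ring, gives a 4.6-fold higher number from compound 1 to compound 3 (0.66 log units; beyond the scatter). Among the compounds shown here, this is the first direct reading at this place, and it shows that the number responds to one more chain carbon between the ring nitrogen and the carboxy group, with the shorter carboxymethyl holding the lower number. The change is modest beside the large 22-fold higher number from compound 1 to compound 2 (1.35 log units; beyond the scatter), which lies elsewhere in the molecule, and nothing available accounts for the shift seen at either place.

The compounds shown carry a carboxylic acid on this chain throughout, so it remains open how a longer chain ending in a carboxylic acid would read, or whether an ester, a primary amide or an amine could stand in its place. From the compounds shown here alone, it also remains open whether sulfanylmethyl in place of sulfanyl would cost as much on the 2-carboxyethyl compound as it does on the carboxymethyl compound.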